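Thiophen-2-yl in place of 4-methylphenyl: series notes

The source may hold more compounds than are shown below. What is called first, only, known or untested is meant among the compounds shown, and "the series" means these compounds.

Measured so far in a physicochemical assay for lipophilicity, measured as octanol-water partition; on this read-out lower numbers stand for lower lipophilicity and higher numbers for higher lipophilicity
- compound 1 `COc1ccc2c(c1)[n+]([O-])c(C#N)c(-c1ccco1)[n+]2[O-]` gives 0.354
- compound 2 `COc1ccc2c(c1)[n+]([O-])c(C#N)c(-c1ccccc1)[n+]2[O-]` gives 1.58
- compound 3 `COc1ccc2c(c1)[n+]([O-])c(C#N)c(-c1ccc(C)cc1)[n+]2[O-]` gives 1.83

Compound 3 stands with compound 2 at the upper end of these numbers, with a gap of a number 0.25 log units higher from compound 2 to compound 3 (within the scatter) between them. Compound 1 lies well away, the step being a number 1.48 log units higher from compound 1 to compound 3 (beyond the scatter) on the same read-out.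

The unmeasured compound 4 `COc1ccc2c(c1)[n+]([O-])c(C#N)c(-c1cccs1)[n+]2[O-]` has thiophen-2-yl in place of 4-methylphenyl on an aromatic carbon and keeps the shared core.

Going by the values given here, the closest evidence is the step of a number 1.23 log units higher from compound 1 to compound 2 (beyond the scatter) together with the one already given for compound 3. Both start from furan-2-yl, which, like thiophen-2-yl, is a five-membered aromatic ring with one hetero atom. Among the compounds with values here, no thiophen-2-yl compound has been measured, so only part of those large steps is expected to reverse. The expected change is a number 0.53 log units lower from compound 3 to compound 4 (beyond the scatter) in this assay as a moderate estimate. Compound 4 is estimated at 1.3 with an expected range from 0.9 to 1.7 on this read-out.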

Compound 4, partition coefficient: 1.11
Beside the measured number, compound 4's estimate is 0.19 log units above it, and the stated range covers the measured number.
By their numbers in this assay, from the lowest: compound 1; then compound 4; then compounds 2 and 3 (each within the scatter of the next).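

Thiophen-2-yl opens a middle level at this position in this assay, which the earlier compounds did not show: the change from furan-2-yl raises the number (a number 0.76 log units higher from compound 1 to compound 4 (beyond the scatter)), and the change from phenyl lowers it (a number 0.47 log units lower from compound 2 to compound 4 (beyond the scatter)). The change from 4-methylphenyl lowers it too (a number 0.72 log units lower from compound 3 to compound 4 (beyond the scatter)), and compound 1 and compound 4 show that two five-membered aromatic rings with one hetero atom do not share one level here, though they differ only in that hetero atom. Nothing in hand gives a reason for these differences.

From the compounds shown here alone, how an amine, a carboxylic acid or a longer alkyl chain would sit on this scale at the same position remains open. Going by these compounds alone, also open is whether a methyl group on the thiophen-2-yl ring would give a step like the one between compound 2 and compound 3.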